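This account rests on a few compounds, and the source may have more. Where it says the series, first, only, none or still open, it means among the compounds named here.

In a functional assay on MGC-803 cells (Homo sapiens) for antiproliferative activity, read by CellTiter-Glo, with a stated time of 72 h (a higher number here means a weaker inhibitor, a lower number a stronger inhibitor), compound 1 (`O=C(NO)c1cccc(/C=C/c2ccnc(-c3cc(F)ccc3O)c2)c1`) gives 2710 nM and compound 2 (`O=C(NO)c1ccc(/C=C/c2ccnc(-c3cc(F)ccc3O)c2)cc1`) gives 1920 nM as its number, and these two values lie within the usual scatter of each other. Compound 3 (`COc1ccccc1-c1cc(/C=C/c2ccc(C(=O)NO)cc2)ccn1`) gives 6350 nM as the highest of the three numbers. It stands beyond the scatter from both of the others, so it is the weakest inhibitor of the three.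

Compound 4 (`O=C(NO)c1ccc(/C=C/c2ccnc(-c3ccc(F)cc3)c2)cc1`) has not yet been measured. It carries 4-fluorophenyl in place of the 2-methoxyphenyl of compound 3, on an aromatic carbon next to the ring nitrogen (4-fluorophenyl in place of 2-methoxyphenyl on an aromatic carbon). For the measured compounds named here, only one measured step bears on this place: putting 2-methoxyphenyl in place of 5-fluoro-2-hydroxyphenyl gave a 3.3-fold higher number from compound 2 to compound 3 (0.52 log units; beyond the scatter) and counts as modest. The incoming 4-fluorophenyl shares a fluorine with the group of compound 2 but has no hydroxyl, so it matches neither end of that step. The expected change is therefore no larger than that modest step, and the estimate is a 1.6-fold lower number from compound 3 to compound 4 (0.20 log units; within the scatter) in this assay as a small drift toward a lower number that need not clear the scatter. For compound 4 the estimated value is 4000 nM with an expected range from 1500 nM to 10000 nM in this reading.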

Compound 4, half-maximal inhibitory concentration: > 10000 nM
Compound 4 gave a limit, no number; the forecaster's own chance of this, stated with the estimate: 2%; middle value at least 2.5-fold (0.39 log units) from the limit.
By their numbers in this assay, from the lowest: compounds 2 and 1 (each within the scatter of the next); then compound 3. At a limit, above all of these: compound 4.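

In this assay, compound 4 gives only a limit and not a number: the limit of > 10000 nM in this assay, at which 1 of the 4 values shown sits. On this aromatic carbon next to the ring nitrogen, an at least 5.2-fold higher number from compound 2 to compound 4 (0.71 log units; beyond the scatter), so a fluorine on the phenyl ring does not by itself keep the activity seen with 5-fluoro-2-hydroxyphenyl, and together with a 3.3-fold higher number from compound 2 to compound 3 (0.52 log units; beyond the scatter), this means that both replacements without the hydroxyl give a higher number. The remaining step, an at least 1.5-fold higher number from compound 3 to compound 4 (0.19 log units; that floor lies within the scatter), is only a floor, so it does not by itself separate 4-fluorophenyl from 2-methoxyphenyl.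

The hydroxyl and the fluorine also still cannot be told apart, since the step to compound 4 removes the hydroxyl and changes where the fluorine sits, and a plain 2-hydroxyphenyl or a 2-aminophenyl at this position would help to show which feature matters. How far the true value of compound 4 lies beyond its limit remains unknown, and so does whether the trend among these phenyl groups would hold with the hydroxamic acid on the other ring position found in compound 1.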